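Shortening the ether side chain on a shared aminoquinoline core

The source may report more compounds than this note shows. Statements on the series, on what has been measured and on what is new or still open speak of the compounds shown alone.

Measured compounds:
Compound 1, `Nc1ccc2cccc(OCCC3CCCCC3)c2n1`: 808 nM
Compound 2, `CC(C)C(C)Oc1cccc2ccc(N)nc12`: 199 nM
Compound 3, `Nc1ccc2cccc(OCC3CCOC3)c2n1`: 115 nM

Three compounds share one core and differ only in the group attached through an oxygen on the aromatic ring. In an assay on cells with melanin-concentrating hormone receptor 1 (Homo sapiens) as the target, read by radioligand binding (on this read-out higher numbers stand for weaker inhibition and lower numbers for stronger inhibition), compound 3 gives the lowest of the three numbers, but its neighbour compound 2 sits within the usual scatter of it; only compound 1, which carries the largest side chain, lies clearly beyond the scatter with a higher number.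

Compound 4, `CCCOc1cccc2ccc(N)nc12`, has not yet been measured. Compared with compound 3 the change is ethyl in place of oxolan-3-yl on a saturated chain carbon bound to an oxygen on an aromatic ring; cut one bond further out, it reads (oxolan-3-yl)methyl to propyl. Within the data shown here, the only step among the measured compounds, a 1.7-fold lower number from compound 2 to compound 3 (0.24 log units; within the scatter), lay within the scatter and exchanged one branched chain for a ring-bearing one; it says little about removing the ring altogether. Compound 1 shows only that a much larger chain gives a higher number.

Among the measured compounds shown here, with no measured step of this kind, compound 4 is expected to land near compound 3, perhaps somewhat higher, a step of a 2.2-fold higher number from compound 3 to compound 4 (0.34 log units; beyond the scatter) that may still fall within the scatter. The estimate for compound 4 is 250 nM, with a range from 80 nM to 800 nM.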

Compound 4, half-maximal inhibitory concentration: 1100 nM
For compound 4 the middle estimate is 4.4-fold (0.64 log units) below the measured one; the whole stated range lies below it.
By their numbers in this assay, from the lowest: compounds 3 and 2 (each within the scatter of the next); then compounds 1 and 4 (each within the scatter of the next).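

In this assay, the plain propyl chain proves far from neutral: replacing the ring end of compound 3 gives a 9.6-fold higher number from compound 3 to compound 4 (0.98 log units; beyond the scatter), and removing the branching of compound 2 gives a 5.5-fold higher number from compound 2 to compound 4 (0.74 log units; beyond the scatter). Shortening the chain does not by itself lower the number at this position, since methyl in place of cyclohexyl on the chain gives a 1.4-fold higher number from compound 1 to compound 4 (0.13 log units; within the scatter), a step within the scatter. No measurement shown here explains these steps.

Still open, as far as these compounds go, is whether the oxygen of the oxolan-3-yl ring matters or whether any small ring would serve, a question that a cyclopentylmethyl group, with carbon in place of that oxygen, could separate. From the compounds shown here alone, how an amine or a carboxylic acid at the end of the propyl chain would read also remains open.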